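This account rests on a few compounds, and the source may have more. Where it says the series, first, only, none or still open, it means among the compounds named here.

Of the compounds shown here, three built on one shared core have been tested in a functional assay on L02 cells (Homo sapiens) for inhibition, read by MTT assay, with a stated time of 48 h; a lower number here means a stronger inhibitor, a higher number a weaker inhibitor. Compound 1 `COc1ccc2c(=O)c(/C=C/C(=O)Nc3cccc(C)c3)coc2c1` carries a 3-methylphenyl group on its amide-type nitrogen, compound 2 `COc1ccc2c(=O)c(/C=C/C(=O)NCc3ccccc3)coc2c1` carries a benzyl group there, and compound 3 `COc1ccc2c(=O)c(/C=C/C(=O)Nc3ccccc3)coc2c1` carries a plain phenyl group. In this assay compound 1 gives only a limit, > 200000 nM. In this assay compound 2 likewise gives only a limit, > 200000 nM. In this assay compound 3 also gives only a limit, > 200000 nM. Compound 3 therefore stands exactly where its two neighbours stand, since (the limit of > 200000 nM in this assay, at which 3 of the 3 values shown sit). The three steps among them, a step that the two limits leave unreadable from compound 1 to compound 2, a step that the two limits leave unreadable from compound 1 to compound 3 and a step that the two limits leave unreadable from compound 2 to compound 3, cannot be given a size, as a limit on both sides hides whatever difference may exist.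

Compound 4 `COc1ccc2c(=O)c(/C=C/C(=O)Nc3ccc(Cl)cc3)coc2c1` has not yet been measured. It differs from compound 3 by chloro in place of hydrogen on an aromatic carbon. Every measured step alters the same group on the amide-type nitrogen, and every one of them is unreadable, so no direction for a chloro in that place can be drawn from them. The expected step in this assay from compound 3 to compound 4 is a step that the limit leaves unreadable from compound 3 to compound 4, most probably ending again at a limit. Compound 4 is estimated at 250000 nM, with a range from 100000 nM to 600000 nM.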

Compound 4, half-maximal inhibitory concentration: > 200000 nM
Compound 4 ended at the assay's limit; the forecaster's own chance of this, stated with the estimate: 85%; the middle value does not contradict the limit.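

No new step can be read from compound 4: its comparisons with compound 1, compound 2 and compound 3 all fail, because each compound gives only a limit in this assay and not a number: the limit of > 200000 nM in this assay, at which 4 of the 4 values shown sit.

The compounds shown leave open how far apart these four really lie, and whether any group on the amide-type nitrogen of the shared core gives a measurable value in this assay.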